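The compounds below may be only part of what the source reports. "The series", "measured", "known", "first", "only" and "open" are said of these compounds alone.

Of the compounds shown here, three sharing one core have so far been measured in an assay on cells for agonist activity at ecdysone receptor (Bombyx mori), read by a luciferase reporter, with a stated time of 24 h; on this read-out lower numbers stand for an effect already at smaller amounts and higher numbers for an effect only at larger amounts of compound. Compound 1 `CC(C)(C)N(NC(=O)c1ccccc1)C(=O)c1ccccc1F` gives 309 nM, compound 2 `CCc1ccccc1C(=O)N(NC(=O)c1ccccc1)C(C)(C)C` gives 589 nM, and compound 3 `CC(C)(C)N(NC(=O)c1cccc(Br)c1)C(=O)c1ccccc1Cl` gives 191 nM. Among the compounds with values here, the only pair that differs in a single place shows a 1.9-fold higher number from compound 1 to compound 2 (0.28 log units; within the scatter), a change too small to be read as a real shift. Compound 3 has the lowest of the three numbers, but its gap to compound 1 lies within the scatter, so those two cannot be ranked against each other; only compound 2 stands clearly higher than compound 3.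

Compound 4 `Cc1ccc(C(=O)NN(C(=O)c2ccccc2Cl)C(C)(C)C)cc1` has not yet been measured. It differs from compound 3 in one place: 4-methylphenyl in place of 3-bromophenyl on a carbonyl carbon. Within the data shown here, no measured step touches this part of the molecule; the single step known concerns a different aromatic carbon, and even that step stayed within the scatter. With nothing in the data pointing to a shift, the expectation for this assay is a number close to that of compound 3, with no movement beyond the scatter in either direction, so a 1.3-fold higher number from compound 3 to compound 4 (0.12 log units; within the scatter) is the step expected. Compound 4 is therefore estimated at 250 nM, with a range from 90 nM to 700 nM.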

Compound 4, half-maximal effective concentration: 18.6 nM
For compound 4 the middle estimate is 13-fold (1.13 log units) above the measured one; measured number outside the range, below it.
By their numbers in this assay, from the lowest: compound 4; then compounds 3, 1 and 2 (each within the scatter of the next, the first and the last beyond it).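

Replacing 3-bromophenyl with 4-methylphenyl on a carbonyl carbon gives a 10-fold lower number from compound 3 to compound 4 (1.01 log units; beyond the scatter) in this assay and is the only single-place step among these compounds that clears the scatter, so the aromatic group on this carbonyl carbon, whose other neighbour is an amide-type nitrogen, is a place where the read-out can move strongly. The computed counts barely separate the two groups: they have the same number of heavy atoms, the same kind of aromatic ring, no hydrogen-bond donors or acceptors and no net charge. A bromine leaves and a methyl group enters at a different ring position. Within the data shown here, nothing available here explains why this swap lowers the number so far.

The step changes both the substituent and its ring position, so it cannot show which of the two matters, and only compounds carrying 4-bromophenyl or 3-methylphenyl on the same core could separate them. Going by these compounds, it also remains open whether a longer chain such as 4-ethylphenyl, or a group such as 4-methoxyphenyl, would hold the number this low.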